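Flipping Three Ring Centres in a Sugar Mimic

The source may report more compounds than this note shows. Statements on the series, on what has been measured and on what is new or still open speak of the compounds shown alone.

Three compounds share one set of atoms and bonds and differ only in how the ring carbons are arranged in space. In an assay for inhibition of alpha-N-acetylgalactosaminidase (Gallus gallus), tested at 1000 uM (on this read-out higher numbers stand for more inhibition at the one concentration tested (going by the name of the read-out) and lower numbers for less inhibition), compound 1 `O=C(O)[C@H]1NC[C@H](O)[C@H](O)[C@H]1O` gives 21%, the highest of the three numbers shown. Compound 2 `O=C(O)[C@H]1NC[C@H](O)[C@@H](O)[C@@H]1O` gives 0.2%, and compound 3 `O=C(O)[C@H]1NC[C@@H](O)[C@H](O)[C@@H]1O` gives 11%. The step of a number 20.8 percentage points lower from compound 1 to compound 2 (beyond the scatter) is beyond the scatter, whereas the step of a number 10 percentage points lower from compound 1 to compound 3 (within the scatter) stays within it; between the two lower compounds the step of a number 10.8 percentage points higher from compound 2 to compound 3 (beyond the scatter) is modest. These steps rest on configuration alone, as the fact that compounds 1 and 2 differ only in the configuration as drawn, the fact that compounds 1 and 3 differ only in the configuration as drawn and the fact that compounds 2 and 3 differ only in the configuration as drawn show.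

Compound 4 `O=C(O)[C@@H]1NC[C@H](O)[C@@H](O)[C@@H]1O` goes one step further: the two compounds have the same atoms and bonds and differ only in configuration as drawn: 3 of 4 stereo elements differ; a stereocentre at a saturated ring carbon is drawn S in compound 1 and R in compound 4; a stereocentre at a saturated ring carbon is drawn S in compound 1 and R in compound 4; a stereocentre at a saturated ring carbon is drawn S in compound 1 and R in compound 4. Two changed centres were enough to lower the number clearly in one case and to leave it roughly unchanged in the other, so three changed centres are expected to give a number no higher than those of compounds 2 and 3, and probably lower. Compound 4 is expected to show the step of a number 16 percentage points lower from compound 1 to compound 4 (beyond the scatter), a fall. For compound 4 the estimate is 5%, in the range 0% to 15%.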

Compound 4, a percentage reported as inhibition, at one concentration (the size of the read-out at that concentration, not a potency): 3.4%
The estimate for compound 4 lay 1.6 percentage points above the measured number; the measured number falls inside the stated range.
By their numbers in this assay, from the lowest: compounds 2, 4, 3 and 1 (each within the scatter of the next, the first and the last beyond it).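

In this assay, the step of a number 17.6 percentage points lower from compound 1 to compound 4 (beyond the scatter) shows that the fall seen with compound 2 also appears when three centres are changed, so this arrangement does not bring back what compound 1 shows. The closest comparison so far is the step of a number 3.2 percentage points higher from compound 2 to compound 4 (within the scatter), where only one stereocentre at a saturated ring carbon differs; starting from compound 2, flipping that single centre makes no change that can be told from the scatter. The step of a number 7.6 percentage points lower from compound 3 to compound 4 (within the scatter) also stays within the scatter, so compound 1 stands clearly apart from compounds 2 and 4 but not from compound 3, and compound 4 cannot be placed in order against compound 3.

All four compounds share the same atoms and bonds, so these numbers say nothing about how a methyl ester in place of the carboxylic acid, or a longer chain on the shared core, would behave. Each number also comes from a single concentration, which leaves open how potency would compare across these arrangements.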